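Swapping the halogen pattern on the anilino group

The source may report more compounds than this note shows. Statements on the series, on what has been measured and on what is new or still open speak of the compounds shown alone.

Within the data shown here, compound 3 `Cc1n[nH]c2ccc(-c3nc4cnc(N5CCN(C)CC5)cn4c3Nc3ccc(F)c(Cl)c3)cc12` is the one member of this small set with a number in hand. In a functional assay on MV4-11 cells (Homo sapiens) for inhibition, with a stated time of 120 h (on this read-out higher numbers stand for weaker inhibition and lower numbers for stronger inhibition), compound 3 gives 2850 nM. Its companions carry no result in this assay: compound 1 `Cc1n[nH]c2ccc(-c3nc4cnc(N5CCN(C)CC5)cn4c3Nc3cccc(F)c3)cc12` is entered there as "not determined" (no result reported), and compound 2 `Cc1n[nH]c2ccc(-c3nc4cnc(N5CCN(C)CC5)cn4c3Nc3cccc(Cl)c3)cc12` is entered there as "not determined" (no result reported), so compound 3 stands alone, with nothing to rank it against. Compound 4 `Cc1n[nH]c2ccc(-c3nc4cnc(N5CCN(C)CC5)cn4c3Nc3ccc(Cl)cc3Cl)cc12` has not yet been measured. It differs from compound 3 in one place: 2,4-dichlorophenyl in place of 3-chloro-4-fluorophenyl on a nitrogen on an aromatic ring. Among the measured compounds shown here, no measured pair in the set shows what such a change does to the read-out, and the single value of compound 3 is the only anchor available. Both compounds keep a chlorine on that aryl ring, and the difference lies only in the second halogen and in the arrangement named above. With no comparison to lean on, the step from compound 3 to compound 4 is expected to be a 1.1-fold higher number from compound 3 to compound 4 (0.05 log units; within the scatter), nothing beyond the scatter. Compound 4 is therefore expected to give about 3200 nM in this assay, with a range from 1000 nM to 10000 nM that reflects the absence of any measured precedent.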

Compound 4, half-maximal inhibitory concentration: 4720 nM
Estimate against measurement, compound 4: 1.5-fold (0.17 log units) below, within the range that was stated.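

In this assay, among these compounds, the exchange of 3-chloro-4-fluorophenyl for 2,4-dichlorophenyl on a nitrogen on an aromatic ring gives a 1.7-fold higher number from compound 3 to compound 4 (0.22 log units; within the scatter) as the first step that can be read at this position. The pair therefore shows that this rearrangement of halogens on the aryl ring, with one chlorine kept and the second halogen exchanged, leaves the read-out within the usual scatter, and compound 3 and compound 4 cannot be told apart. No supporting measurement bears on this result.

On these data alone, what a single halogen on this ring does to the read-out remains open, as does the effect of a group of a different kind, such as methoxy, an amine or a carboxylic acid, on the same ring. As far as these compounds go, it is also open whether either would carry the number beyond the scatter.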